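Solubility notes on an amide series: outlook for compound 4

The source may hold more compounds than are shown below. What is called first, only, known or untested is meant among the compounds shown, and "the series" means these compounds.

Of the compounds shown here, three have been measured in a physicochemical assay for solubility, read by HPLC, at pH 6.8; on this read-out lower numbers stand for lower solubility and higher numbers for higher solubility. Compound 1 `CC(C)(C)c1cc(NC(=O)[C@@H]2CCCCN2C(=O)c2ccc(Cl)cc2)no1` returns only a limit, < 0.1 ug/mL, which is the limit of < 0.1 ug/mL in this assay, at which 1 of the 3 values shown sits, and not a number. Compound 2 `CC(C)(C)c1cc(NC(=O)[C@@H]2CCCCN2C(=O)C2CCCCC2)no1` gives 6.4 ug/mL in this assay. Compound 3 `CC(C)(C)c1cc(NC(=O)[C@@H]2CCCCN2C(=O)CC2CCOCC2)no1` gives 52 ug/mL in this assay and stands highest of the two numbers available, with compound 2 as its nearest neighbour. All measured steps sit on the same carbonyl carbon: an at least 64-fold higher number from compound 1 to compound 2 (1.80 log units; beyond the scatter), an at least 520-fold higher number from compound 1 to compound 3 (2.71 log units; beyond the scatter) and an 8.1-fold higher number from compound 2 to compound 3 (0.91 log units; beyond the scatter).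

Compound 4 `CC(=O)N1CCN(C(=O)N2CCCC[C@H]2C(=O)Nc2cc(C(C)(C)C)on2)CC1` has not yet been measured; it differs from compound 3 by 4-acetylpiperazin-1-yl in place of (oxan-4-yl)methyl on a carbonyl carbon. Every exchange at this carbonyl carbon so far has moved the number beyond the scatter, and the steps leading to compound 3 were the largest, so a further exchange at the same position is expected to shift this assay again, most likely upward, by a modest step rather than a large one. Compound 4 is therefore expected to give 120 ug/mL in this assay, within a range from 40 ug/mL to 400 ug/mL. This corresponds to an expected step of a 2.3-fold higher number from compound 3 to compound 4 (0.36 log units; beyond the scatter).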

Compound 4, solubility: 62 ug/mL
Compound 4: the middle estimate sits 1.9-fold (0.29 log units) above what was measured; measured number inside the range.
By their numbers in this assay, from the lowest: compound 2; then compounds 3 and 4 (each within the scatter of the next). At a limit, below all of these: compound 1.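

Working notes after compound 4. In this assay, among these compounds, the exchange on the carbonyl carbon whose other neighbours are amide-type nitrogen in a ring now gives the first pair that this read-out cannot separate (a 1.2-fold higher number from compound 3 to compound 4 (0.08 log units; within the scatter)), with 4-acetylpiperazin-1-yl and (oxan-4-yl)methyl standing level despite their different ring hetero atoms and the extra acetyl carbonyl. Cyclohexyl stays clearly apart from this new group (a 9.7-fold higher number from compound 2 to compound 4 (0.99 log units; beyond the scatter)), so among the listed compounds the two rings carrying hetero atoms, in compound 3 and compound 4, share one level, while compound 2, whose ring has none, stands lower. The value of compound 1 is a limit and not a number, so the widest gap, (an at least 620-fold higher number from compound 1 to compound 4 (2.79 log units; beyond the scatter)), is a bound only: the limit of < 0.1 ug/mL in this assay, at which 1 of the 4 values shown sits.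

Going by these compounds, whether a free secondary amine or a carboxylic acid in place of the acetyl group would lift the number past the level of compound 3 and compound 4 stays open. How the read-out responds to exchanges elsewhere on the shared core also stays open, since all the compounds shown differ only on this carbonyl carbon.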